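Amino for Chloro Carried from One Isomer to Another

This account rests on a few compounds, and the source may have more. Where it says the series, first, only, none or still open, it means among the compounds named here.

Compound 1 `ClCc1ccccc1Cn1cnc2c(Cl)nc(Cl)nc21` and compound 2 `ClCc1cccc(Cn2cnc3c(Cl)nc(Cl)nc32)c1` are built from the same atoms joined differently; the difference between the two cores is not broken down here. In a functional assay on MDA-MB-231 cells (Homo sapiens) for cytotoxicity, read by sulforhodamine B assay, with a stated time of 48 h (on this read-out lower numbers stand for stronger inhibition of growth and higher numbers for weaker inhibition of growth), compound 1 gives 330 nM, and compound 2 gives 1950 nM. Compound 3 `Nc1nc(Cl)c2ncn(Cc3ccccc3CCl)c2n1` derives from compound 1 by amino in place of chloro on an aromatic carbon, and in this assay compound 3 gives 2950 nM, a step of an 8.9-fold higher number from compound 1 to compound 3 (0.95 log units; beyond the scatter). Compound 4 `Nc1nc(Cl)c2ncn(Cc3cccc(CCl)c3)c2n1` derives from compound 2 by amino in place of chloro on an aromatic carbon, the same change at the same place. For compound 4 in this assay a step of about a 6.7-fold higher number from compound 2 to compound 4 (0.82 log units; beyond the scatter) is expected, resting on the step of an 8.9-fold higher number from compound 1 to compound 3 (0.95 log units; beyond the scatter) observed for compound 3. Compound 4 is therefore estimated at 13000 nM, within a range from 4500 nM to 40000 nM.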

Compound 4, concentration for 50% growth inhibition: 12000 nM
For compound 4 the middle estimate is 1.1-fold (0.03 log units) above the measured one; low and high end bracket the measured number.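

In this assay, amino in place of chloro on an aromatic carbon gives a 6.2-fold higher number from compound 2 to compound 4 (0.79 log units; beyond the scatter), and this step agrees with the one seen on the other core: the same change on two cores in this assay, an 8.9-fold higher number (0.95 log units; beyond the scatter) from compound 1 to compound 3 and a 6.2-fold higher number (0.79 log units; beyond the scatter) from compound 2 to compound 4, 1.5-fold (0.16 log units) apart, within the scatter of two such steps. Across these two cores, the change therefore carries over, with weaker inhibition of growth on both. Among these compounds, this rests on only two pairs in a single assay, so it shows neither why the change has this effect nor that it would hold on any further core.

The compounds shown leave open whether a methylamino or dimethylamino group in the same place would follow the amino group. They also leave open whether a methoxy group there would give a step of similar size.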